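Methyl in place of fluoro on the aryl ring of compound 2

The source may hold more compounds than are shown below. What is called first, only, known or untested is meant among the compounds shown, and "the series" means these compounds.

The shared core is that of compound 2 `Cn1nnnc1SCC(=O)N/N=C/c1ccccc1F`. Two numbers are reported in a functional assay on A549 cells (Homo sapiens) for cytotoxicity, read by XTT assay, with a stated time of 24 h; a higher number here means a weaker inhibitor, a lower number a stronger inhibitor: compound 2 gives 9000000 nM, and compound 3 `Cn1nnnc1SCC(=O)N/N=C/c1cccc(Cl)c1` gives 7500000 nM, the two lying within the scatter of each other. Compound 1 `Cn1nnnc1SCC(=O)N/N=C/c1ccc(O)cc1` reaches only a limit of this assay, > 10000000 nM. Compound 4 `Cc1ccccc1/C=N/NC(=O)CSc1nnnn1C` is not yet measured. It differs from compound 2 by methyl in place of fluoro on an aromatic carbon. Among the measured compounds shown here, no measured pair carries this change, so no step beyond the scatter is expected in either direction. Compound 4 is estimated at 9000000 nM, between 4000000 nM and 20000000 nM. The step of no change at the digits printed from compound 2 to compound 4 (within the scatter) is expected to stay within the scatter.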

Compound 4, half-maximal inhibitory concentration: > 10000000 nM
Compound 4 was reported as a limit; the forecaster's own chance of this, stated with the estimate: 40%; middle value at least 1.1-fold (0.04 log units) away from the limit.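

In this assay, methyl in place of fluoro on an aromatic carbon, ortho to a large group, gives an at least 1.1-fold higher number from compound 2 to compound 4 (0.04 log units; that floor lies within the scatter). For compound 4, > 10000000 nM is a limit of the assay and not a number. This single change therefore yields only a floor, and the series now has a second compound at that limit: the limit of > 10000000 nM in this assay, at which 2 of the 4 values shown sit.

Going by these compounds, the true size of the step stays open, including whether it passes the scatter. Also open, on these data alone, is whether an amine or a carboxylic acid on this aromatic carbon would give a lower number.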